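The source may hold more compounds than are shown below. What is called first, only, known or untested is meant among the compounds shown, and "the series" means these compounds.

The three compounds measured so far share one core, shown in compound 1 `O=c1ccoc2cc(OCc3cn(Cc4ccccc4)nn3)ccc12`, and differ only in the group attached to the saturated chain carbon bound to an aromatic nitrogen. In a functional assay on A549 cells (Homo sapiens) for cytotoxicity, read by MTT assay, with a stated time of 48 h (on this read-out higher numbers stand for weaker inhibition and lower numbers for stronger inhibition), compound 1 gives > 100000 nM, which is a limit of the assay and not a number. Compound 2 `Cc1ccc(Cn2cc(COc3ccc4c(=O)ccoc4c3)nn2)cc1` carries a methyl in place of hydrogen on an aromatic carbon of that group, and in this assay compound 2 gives 50700 nM. Compound 3 `O=c1ccoc2cc(OCc3cn(Cc4cccc(Br)c4)nn3)ccc12` carries a bromo in place of hydrogen on an aromatic carbon, and in this assay compound 3 gives > 100000 nM, again a limit rather than a number. Compound 3 therefore stands at the weak end of what this assay can report, and it is not alone there: the limit of > 100000 nM in this assay, at which 2 of the 3 values shown sit. The measured steps are all modest: an at least 1.9-fold lower number from compound 1 to compound 2 (0.29 log units; that floor lies within the scatter), an at least 1.9-fold higher number from compound 2 to compound 3 (0.29 log units; that floor lies within the scatter), and a step that the two limits leave unreadable from compound 1 to compound 3.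

Compound 4 `Cc1ccccc1Cn1cc(COc2ccc3c(=O)ccoc3c2)nn1` differs from compound 3 by 2-methylphenyl in place of 3-bromophenyl on a saturated chain carbon bound to an aromatic nitrogen. The step from compound 2 to compound 3, which also swaps the whole aromatic group, stayed within the scatter, so the expected change is likewise small: an at least 1.2-fold lower number from compound 3 to compound 4 (0.09 log units; that floor lies within the scatter). Compound 4 is estimated at 80000 nM, between 35000 nM and 200000 nM, with a fair chance that only a limit is reported.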

Compound 4, half-maximal inhibitory concentration: > 100000 nM
Compound 4: only a limit was reported (the forecaster's own chance of this, stated with the estimate: 50%); middle value at least 1.2-fold (0.09 log units) from the limit.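

In this assay compound 4 gives > 100000 nM, which is a limit of the assay and not a number. Replacing 4-methylphenyl with 2-methylphenyl on the saturated chain carbon bound to an aromatic nitrogen gives an at least 1.9-fold higher number from compound 2 to compound 4 (0.29 log units; that floor lies within the scatter), so the measured number seen with 4-methylphenyl does not carry over to every methylphenyl group at this place, although the size of the step cannot be separated from ordinary scatter. The steps from compound 3 to compound 4 and from compound 1 to compound 4 have a limit at both ends and cannot be read, and the weak end of the scale now holds most of the series: the limit of > 100000 nM in this assay, at which 3 of the 4 values shown sit.

The compounds shown leave open how compound 1, compound 3 and compound 4 rank against one another, and whether the single measured number for a methylphenyl group marks a real preference or only a value close to the limit. They also leave open what 3-methylphenyl would give at this place, and whether a phenyl group carrying an amine or a carboxylic acid would bring a clearly stronger number in this assay.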